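Nitro for bromo on the distal ring of compound 3

A few compounds are considered here, and "the series" means these few. Any claim that something is new, unique, unknown or untested is made for them only; others in the source may bear on it.

Compound 3 `CCOC(=O)CCCCCOc1cccc(CN(C(=O)c2ccc(-c3cccc(Br)c3)cc2)C(C)C)c1` carries a 3-bromophenyl group on the shared core. In an ADME assay on Raji cells (Homo sapiens) for cytotoxicity, read by CellTiter-Glo and resazurin assay, with a stated time of 72 h (a lower number here means that less compound is needed, a higher number that more compound is needed for the effect), compound 3 gives > 26000 nM, which is a limit of the assay and not a number. Its two relatives, compound 1 `CCOC(=O)CCCCCOc1cccc(CN(C(=O)c2ccc(-c3cccc(NC(C)=O)c3)cc2)C(C)C)c1` and compound 2 `CCOC(=O)CCCCCOc1cccc(CN(C(=O)c2ccc(-c3cnc(OC)nc3OC)cc2)C(C)C)c1`, are known in the same way. Compound 1 gives > 26000 nM, again a limit. Compound 2 gives > 26000 nM, also a limit. The measured steps a step that the two limits leave unreadable from compound 1 to compound 2, a step that the two limits leave unreadable from compound 1 to compound 3 and a step that the two limits leave unreadable from compound 2 to compound 3 therefore cannot be read for size; what stands is the limit of > 26000 nM in this assay, at which 3 of the 3 values shown sit.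

The step at hand leads to compound 4 `CCOC(=O)CCCCCOc1cccc(CN(C(=O)c2ccc(-c3cccc([N+](=O)[O-])c3)cc2)C(C)C)c1`; the change is nitro in place of bromo on an aromatic carbon. Among the measured compounds shown here, none of the measured steps has a readable size, and no compound so far reaches a number in this assay. With three limits behind it, compound 4 is expected to stay at the limit as well. The expected step is a step that the limit leaves unreadable from compound 3 to compound 4, which is to say none that can be read. For compound 4 the estimate is 40000 nM, with a range from 15000 nM to 120000 nM, most likely reported only as a limit.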

Compound 4, half-maximal effective concentration: > 26000 nM
Compound 4: no number, only a limit; the forecaster's own chance of this, stated with the estimate: 85%; the middle value is on the limit's open side.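

Compound 4 gives > 26000 nM in this assay, a limit and not a number, so its steps from compound 1, compound 2 and compound 3 cannot be read for size. The compounds shown leave open whether any group at this place on the shared core gives a number in this assay: the limit of > 26000 nM in this assay, at which 4 of the 4 values shown sit.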